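The source may hold more compounds than are shown below. What is called first, only, known or untested is meant among the compounds shown, and "the series" means these compounds.

Among the measured compounds shown here, compound 1, with structure `O=C(O)CC/C=C\CO[C@H]1C(OCc2ccc(-c3ccc(CO)cc3)cc2)CC[C@@H]1N1CCCCCC1`, is one of two compounds measured in a functional assay for antagonist activity at thromboxane A2 receptor (Rattus norvegicus) (a lower number here means tighter binding, a higher number weaker binding), where compound 1 gives 20 nM. Its companion, compound 2, structure `O=C(O)CC/C=C\CO[C@H]1[C@@H](OCc2ccc(-c3ccccc3CO)cc2)CC[C@@H]1N1CCCCCC1`, gives in this assay 12.6 nM. Compound 1 thus carries the higher of the two numbers, but the gap to compound 2 lies within the usual scatter of this kind of measurement, so the two cannot be told apart on these data.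

Compound 3, structure `CC(=O)NCc1ccc(-c2ccc(COC3CC[C@H](N4CCCCCC4)[C@H]3OC/C=C\CCC(=O)O)cc2)cc1`, has not yet been measured in this assay. It differs from compound 1 in one place: acetamido in place of hydroxy on a saturated chain carbon bound to an aromatic carbon. For the measured compounds named here, no pair of measured compounds shows the effect of this exchange, and the two measured values offer no guidance on it. The account therefore expects no step beyond the scatter, in either direction, and puts the step from compound 1 to compound 3 at a 1.3-fold higher number from compound 1 to compound 3 (0.10 log units; within the scatter) as an estimate. Compound 3 is estimated to give 25 nM in this assay, with a plausible range from 8 nM to 80 nM.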

Compound 3, dissociation constant: 20 nM
The estimate for compound 3 lay 1.3-fold (0.10 log units) above the measured number; the range from low to high includes it.
By their numbers in this assay, from the lowest: compounds 2, 1 and 3 (each within the scatter of the next).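

In this assay, among the compounds shown here, acetamido in place of hydroxy on a saturated chain carbon bound to an aromatic carbon gives no change at the digits printed from compound 1 to compound 3 (within the scatter), the first reading at this place: with 4 heavy atoms entering for 1 leaving, the larger group brings no step beyond the scatter. Both groups count 1 hydrogen-bond donor and 1 hydrogen-bond acceptor, so this pair keeps those counts level and does not test the loss of either. No evidence at hand bears on why the number holds across this exchange.

The compounds shown leave open how an amine, a carboxylic acid or a longer acyl chain such as butyramido would read at this place in this assay. With a single pair behind it, the result also cannot say whether the hydroxymethyl group could give way to a plain methyl, which would remove the hydrogen-bond donor and acceptor that both groups here share.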